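Moving the benzyl group of compound 1

The source may hold more compounds than are shown below. What is called first, only, known or untested is meant among the compounds shown, and "the series" means these compounds.

Compound 1 `COc1ccc(NC(=O)NCCNS(=O)(=O)c2ccc(-c3ccccc3OCc3ccccc3)s2)cc1`: > 50000 nM (a limit)
Compound 2 `COc1cccc(NC(=O)NCCNS(=O)(=O)c2ccc(-c3ccccc3OCc3ccccc3)s2)c1`: 1700 nM
Compound 3 `O=C(NCCNS(=O)(=O)c1ccc(-c2ccccc2OCc2ccccc2)s1)Nc1cccc([N+](=O)[O-])c1`: 2800 nM

In a functional assay on HL-60 cells (Homo sapiens) for inhibition, read by CCK-8 assay, with a stated time of 48 h (a lower number here means a stronger inhibitor, a higher number a weaker inhibitor), compound 1 gives > 50000 nM, which is only a limit and not a number. Compound 4 `COc1ccc(NC(=O)NCCNS(=O)(=O)c2ccc(-c3ccccc3Oc3ccc([N+](=O)[O-])c([N+](=O)[O-])c3)s2)cc1` keeps the 4-methoxyphenyl of compound 1 and differs from it as follows: 3,4-dinitrophenyl in place of benzyl on an oxygen on an aromatic ring. In words, 3,4-dinitrophenyl stands in place of benzyl on an oxygen on an aromatic ring.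

Among the measured compounds shown here, no measured step changes that place. The closest evidence is indirect: an at least 29-fold lower number from compound 1 to compound 2 (1.46 log units; beyond the scatter) and an at least 17-fold lower number from compound 1 to compound 3 (1.25 log units; beyond the scatter) are both large, but both are changes on an amide-type nitrogen, while a 1.6-fold higher number from compound 2 to compound 3 (0.22 log units; within the scatter) stays within the scatter. These steps show that one change can take compound 1 well off its limit, so a lower number is expected here, of uncertain size. The expected step is an at least 6.2-fold lower number from compound 1 to compound 4 (0.79 log units; beyond the scatter). For compound 4 the estimate is 8000 nM, with an expected range of 1500 nM to 40000 nM.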

Compound 4, half-maximal inhibitory concentration: 5400 nM
Compound 4: the middle estimate sits 1.5-fold (0.17 log units) above what was measured, within the range that was stated.
By their numbers in this assay, from the lowest: compounds 2, 3 and 4 (each within the scatter of the next, the first and the last beyond it). At a limit, above all of these: compound 1.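

The oxygen on an aromatic ring proves to be a second place where one change moves the 4-methoxyphenyl compound off its limit: in this assay, 3,4-dinitrophenyl in place of benzyl gives an at least 9.2-fold lower number from compound 1 to compound 4 (0.96 log units; beyond the scatter). The earlier steps shown here off that limit were all changes on an amide-type nitrogen, whereas here the 4-methoxyphenyl stays. Compound 1 stands at a limit, so the true size of this step stays unknown: the limit of > 50000 nM in this assay, at which 1 of the 4 values shown sits.

From the compounds shown here alone, whether a single nitro group, or an amine in place of the nitro groups, would serve as well remains open. So does the effect of 3,4-dinitrophenyl on compound 2.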